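Swapping methyl for cyclopropyl on a sulfonamide chain

This account rests on a few compounds, and the source may have more. Where it says the series, first, only, none or still open, it means among the compounds named here.

Compound 3 `CCNS(=O)(=O)CCNc1nonc1/C(=N/O)Nc1ccc(F)c(Br)c1` gives 95 nM in an assay on isolated protein for inhibition of Indoleamine 2,3-dioxygenase 1 (Homo sapiens), read by fluorescence, with a stated time of 60 min; a higher number here means a weaker inhibitor, a lower number a stronger inhibitor. Compound 1 `NNc1nonc1/C(=N/O)Nc1ccc(F)c(Br)c1` gives 108 nM and compound 2 `NS(=O)(=O)CCNc1nonc1/C(=N/O)Nc1ccc(F)c(Br)c1` gives 71 nM; there was a 1.1-fold lower number from compound 1 to compound 3 (0.06 log units; within the scatter) and a 1.3-fold higher number from compound 2 to compound 3 (0.13 log units; within the scatter), so compound 3 sits within the scatter of both. Compound 4 `O=S(=O)(CCNc1nonc1/C(=N/O)Nc1ccc(F)c(Br)c1)NCC1CC1` differs from compound 3 by cyclopropyl in place of methyl on a saturated chain carbon bound to a sulfonamide nitrogen. The nearest measured change, a 1.3-fold higher number from compound 2 to compound 3 (0.13 log units; within the scatter), altered the same sulfonamide nitrogen without effect beyond the scatter, and a 1.5-fold lower number from compound 1 to compound 2 (0.18 log units; within the scatter) shows that adding the whole sulfamoylethyl chain also moved little. Growing the group on that nitrogen further is therefore expected to change nothing beyond the scatter, an expected step of no change at the digits printed from compound 3 to compound 4 (within the scatter). Compound 4 is expected to give 95 nM, likely between 45 nM and 200 nM.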

Compound 4, half-maximal inhibitory concentration: 312 nM
The estimate for compound 4 lay 3.3-fold (0.52 log units) below the measured number, outside the stated range (above it).
By their numbers in this assay, from the lowest: compounds 2, 3 and 1 (each within the scatter of the next); then compound 4.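

Among these compounds, the group on the sulfonamide nitrogen is less free than the earlier compounds suggested. In this assay, among the compounds shown here, ethyl on that nitrogen stayed within the scatter of the unsubstituted sulfonamide, but cyclopropyl in place of methyl on the saturated chain carbon gives a 3.3-fold higher number from compound 3 to compound 4 (0.52 log units; beyond the scatter) and cyclopropylmethyl in place of hydrogen gives a 4.4-fold higher number from compound 2 to compound 4 (0.64 log units; beyond the scatter) as the first change here beyond the scatter, toward a weaker inhibitor. Nothing available explains this loss.

From the compounds shown here alone, whether the loss comes with the ring or simply with the larger group stays open. A straight propyl or butyl chain on that nitrogen would separate the two.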